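Cyanoguanidine series: chain extension and dimethylamino variant

The source may report more compounds than this note shows. Statements on the series, on what has been measured and on what is new or still open speak of the compounds shown alone.

Measured so far in a functional assay on the whole organism with Rattus norvegicus as the target; on this read-out lower numbers stand for an effect already at smaller amounts and higher numbers for an effect only at larger amounts of compound:
compound 1 `CC/N=C(/NC#N)NCCCCn1nc(-c2ccccc2)ccc1=O` gives 60.7 mg/kg
compound 2 `C/N=C(/NC#N)NCCCCCn1nc(-c2ccccc2)ccc1=O` gives 76.2 mg/kg
compound 3 `C/N=C(\S)NCCCCn1nc(-c2ccccc2)ccc1=O` gives 17.3 mg/kg

Compound 2 holds the top number of the three, but this rests on little: a 1.3-fold higher number from compound 1 to compound 2 (0.10 log units; within the scatter) is within the scatter, so compounds 1 and 2 cannot be told apart. Only the thiourea compound 3 separates, with a 3.5-fold lower number from compound 1 to compound 3 (0.55 log units; beyond the scatter) and a 4.4-fold lower number from compound 2 to compound 3 (0.64 log units; beyond the scatter).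

Compound 4 `CN(C)/C(=N/CCCCCCn1nc(-c2ccccc2)ccc1=O)NC#N` is not yet measured. It differs from compound 2 by a group of 9 heavy atoms (5 carbon, 4 nitrogen; no ring) in place of a group of 7 heavy atoms (3 carbon, 4 nitrogen; no ring), on a saturated chain carbon, five bonds along the chain from an aromatic nitrogen. The cyanoguanidine unit is kept; the change is one of chain length and of substitution on its terminal nitrogen.

Among the compounds with values here, the only measured step that bears on this is the chain extension from compound 1 to compound 2, which stayed within the scatter. Within the data shown here, no measured step tests the dimethylamino variant of the cyanoguanidine, so that part of the change is uncharted. The steps to compound 3 concern the thiourea and do not apply.

Expectation for compound 4 in this assay: no step beyond the scatter from compound 2, with a 1.1-fold higher number from compound 2 to compound 4 (0.05 log units; within the scatter) as the estimated step. Compound 4 is therefore estimated at 85 mg/kg, within 40 mg/kg to 180 mg/kg.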

Compound 4, dose for half-maximal effect: 92.5 mg/kg
Beside the measured number, compound 4's estimate is 1.1-fold (0.04 log units) below it; the range from low to high includes it.
By their numbers in this assay, from the lowest: compound 3; then compounds 1, 2 and 4 (each within the scatter of the next).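

Working notes on the series. In this assay the group at this place, on a saturated chain carbon, five bonds along the chain from an aromatic nitrogen, changes with a 1.2-fold higher number from compound 2 to compound 4 (0.08 log units; within the scatter) as its result, so this change stays inside the scatter even though it reaches the terminal nitrogen of the cyanoguanidine and not only the chain. The earlier compounds shown here tested the chain alone; here a group with 1 hydrogen-bond donor in place of one with 2 hydrogen-bond donors also leaves compound 4 inseparable from compound 2, and by the printed order compounds 1, 2 and 4 form one run, each within the scatter of the next, with only the thiourea compound 3 standing apart. No measurement on these compounds accounts for this flat read-out.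

Chain length and dimethylamino substitution arrive together in this one step, so neither can be read alone, and two opposing contributions cannot be excluded. Still open, going by these compounds, are a thiourea on a longer chain, as well as a cyclic amine such as pyrrolidine on the cyanoguanidine terminus.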